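Isopropyl for hydroxymethyl on the biaryl of compound 1

The source may hold more compounds than are shown below. What is called first, only, known or untested is meant among the compounds shown, and "the series" means these compounds.

Compound 1 `CC[C@@H](Nc1c(C#N)c(-c2ccc(-c3ccccc3CO)cc2)nc2cnccc12)C(N)=O` is one of two measured members of this series. In a physicochemical assay for lipophilicity, read by HPLC, at pH 7.5 (on this read-out lower numbers stand for lower lipophilicity and higher numbers for higher lipophilicity), compound 1 gives 2.1. Compound 2 `CC[C@@H](Nc1c(C#N)c(-c2ccc(-c3cccc(C)c3F)cc2)nc2cnccc12)C(=O)O` gives 2.1 in this assay, so compound 1 stands level with compound 2 at the digits shown, the two values lying within the usual scatter of each other. Among the measured compounds shown here, no measured pair in the set differs in a single place, so no measured step is available to calibrate the change that follows.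

Compound 3 `CC[C@@H](Nc1c(C#N)c(-c2ccc(-c3ccccc3C(C)C)cc2)nc2cnccc12)C(N)=O` is not yet measured. Compared with compound 1, the change is isopropyl in place of hydroxymethyl on an aromatic carbon. For the measured compounds named here, with no measured step of the same kind to rest on, the expectation for compound 3 is a step well beyond the scatter, upward, of a number 1.20 log units higher from compound 1 to compound 3 (beyond the scatter) in this assay. The estimate for compound 3 in this assay is accordingly 3.3, expected to fall between 2.7 and 3.9.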

Compound 3, distribution coefficient: 3.5
Beside the measured number, compound 3's estimate is 0.20 log units below it; the measured number falls inside the stated range.
By their numbers in this assay, from the lowest: compounds 1 and 2 (each within the scatter of the next); then compound 3.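

Among the compounds shown here, this position on the biaryl is not neutral in this assay: the first single-place step reads a number 1.40 log units higher from compound 1 to compound 3 (beyond the scatter) and is large. Hydroxymethyl has 1 hydrogen-bond donor and 1 hydrogen-bond acceptor, isopropyl has 0 hydrogen-bond donors and 0 hydrogen-bond acceptors, and neither carries a net charge, yet this one step cannot separate the loss of oxygen from the gain in carbon. No measurement shown here accounts for the size of the step.

As far as these compounds go, how the read-out responds to methoxy, ethyl or aminomethyl on this aromatic carbon stays open, and these groups would help divide the step between its two parts. Also open, from the compounds shown here alone, is whether a similar step holds alongside the carboxylic acid of compound 2, which differs from compound 1 in more than one place.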